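The source may hold more compounds than are shown below. What is called first, only, known or untested is meant among the compounds shown, and "the series" means these compounds.

Among the compounds with values here, compound 1, `CC(C)(C)C1=NN(c2cccc(F)c2)C(c2ccc(O)cc2)C1`, is one of two compounds measured in an assay on isolated protein for inhibition of protein kinase C zeta type (Homo sapiens), with a stated time of 4 min, tested at 62.5 uM; on this read-out lower numbers stand for less inhibition and higher numbers for more inhibition at the one concentration tested (going by the name of the read-out). In this assay compound 1 gives 98.1%. The other measured compound, compound 2, `CC(C)(C)C1=NN(c2cccc(C(F)(F)F)c2)C(c2ccc(O)cc2)C1`, gives 96.1% in this assay. Within the data shown here, the only measured step, a number 2 percentage points lower from compound 1 to compound 2 (within the scatter), changes a group on the aromatic ring that sits on the amine nitrogen of the five-membered ring, and it leaves the read-out where it was: the two numbers lie within the scatter of each other, so the inhibition in this assay is level between the two compounds.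

Compound 3, `CC(C)(C)C1=NN(c2ccc(Cl)cc2Cl)C(c2ccc(O)cc2)C1`, differs from compound 1 at the same aromatic ring: 2,4-dichlorophenyl in place of 3-fluorophenyl on an amine nitrogen in a ring. Among the measured compounds shown here, no measured step swaps the whole ring or adds chlorine, so the only guide is that the one change made at this ring so far, from compound 1 to compound 2, stayed within the scatter. On that basis the step from compound 1 to compound 3 in this assay is expected to be small, a number 5.1 percentage points lower from compound 1 to compound 3 (within the scatter), with no direction beyond the scatter.

Compound 3 is therefore estimated at 93% in this assay, within a range from 78% to 100%.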

Compound 3, a percentage reported as inhibition, at one concentration (the size of the read-out at that concentration, not a potency): 71%
Estimate against measurement, compound 3: 22 percentage points above, and the stated range ends above it.
By their numbers in this assay, from the lowest: compound 3; then compounds 2 and 1 (each within the scatter of the next).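

The aromatic ring on the amine nitrogen of the five-membered ring turns out not to be indifferent to what it carries: in this assay, 2,4-dichlorophenyl in place of 3-fluorophenyl gives a number 27.1 percentage points lower from compound 1 to compound 3 (beyond the scatter) and so moves the read-out by more than the usual scatter. The earlier change at this ring, a number 2 percentage points lower from compound 1 to compound 2 (within the scatter), left the two numbers level, so the position accepts one change without a visible effect but not every change, although compound 3 at 71% still shows clear inhibition at the one concentration tested. The data offered here contain no independent measurement that accounts for this drop.

This single step swaps one fluorine for two chlorines, so it cannot say whether the kind of halogen, their number or their places on the ring goes with the lower number. A plain phenyl, 3-chlorophenyl or 4-chlorophenyl would separate these possibilities, while a ring bearing an amine or a carboxylic acid would show how this position responds to groups quite unlike the halogens and trifluoromethyl seen so far.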